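Methoxy on the phenoxy ring of a nitrocatechol ketone

The source may hold more compounds than are shown below. What is called first, only, known or untested is meant among the compounds shown, and "the series" means these compounds.

Measured compounds:
compound 1, `O=C(COc1ccccc1)c1cc(O)c(O)c([N+](=O)[O-])c1`, 39%
compound 2, `CCN(CC)CCC(=O)c1cc(O)c(O)c([N+](=O)[O-])c1`, 26%
compound 3, `O=C(COc1cccc2ccccc12)c1cc(O)c(O)c([N+](=O)[O-])c1`, 37%

In an assay on the whole organism (brain) for inhibition of Catechol O-methyltransferase (Mus musculus), with a stated time of 1 h, at a dose of 30 mg/kg by the oral route (on this read-out lower numbers stand for less inhibition and higher numbers for more inhibition at the one dose given (going by the name of the read-out)), compound 1 gives 39%, the highest of the three numbers, though compound 3 with 37% lies within the scatter of it. For the measured compounds named here, the only step recorded between compounds that differ in one place is a number 13 percentage points lower from compound 1 to compound 2 (beyond the scatter), and it concerns the chain end, not the phenoxy ring. The change to the new compound 4, `COc1ccc(OCC(=O)c2cc(O)c(O)c([N+](=O)[O-])c2)cc1`, is methoxy in place of hydrogen on an aromatic carbon. Going by the values given here, no measured step touches the phenoxy ring itself; the two values of compound 1 and compound 3 show that a larger aryloxy group leaves the number within the scatter. On that basis compound 4 is expected to stay close to compound 1, with a number 1 percentage points lower from compound 1 to compound 4 (within the scatter) expected to lie within the scatter. Compound 4 is estimated at 38%, with a range from 25% to 50%.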

Compound 4, a percentage reported as inhibition, in the whole organism at one dose (the size of the read-out at that dose, not a potency): 41%
The estimate for compound 4 lay 3 percentage points below the measured number; the measured number falls inside the stated range.
By their numbers in this assay, from the lowest: compound 2; then compounds 3, 1 and 4 (each within the scatter of the next).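

Methoxy in place of hydrogen on an aromatic carbon of the phenoxy ring, para to a large group, is the first change shown on that ring itself. In this assay, the step is a number 2 percentage points higher from compound 1 to compound 4 (within the scatter), so this change at this position leaves the read-out within the scatter, at this one dose and time. Nothing available explains this outcome.

The compounds shown leave open whether another group at this carbon, such as an amine or a carboxylic acid, would also leave the number within the scatter. They also leave open whether methoxy on another carbon of the phenoxy ring would behave as it does here, and a single dose cannot show whether compound 1 and compound 4 differ in potency.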